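Fluoro on the anilide ring of compound 1

The compounds below may be only part of what the source reports. "The series", "measured", "known", "first", "only" and "open" are said of these compounds alone.

Measured so far, in a functional assay on HepG2 cells (Homo sapiens) for inhibition, read by MTT assay, with a stated time of 72 h; a higher number here means a weaker inhibitor, a lower number a stronger inhibitor:
Compound 1, `O=C(Nc1ccc(Oc2ccnc3[nH]ccc23)cc1)c1cn(-c2ccccc2)c2ccccc2c1=O`, gives 2250 nM.
Compound 2, `O=C(Nc1ccc(Oc2ccnc3[nH]ccc23)cc1)c1cn(-c2ccc(F)c(Cl)c2)c2ccccc2c1=O`, gives 1120 nM.
Compound 3, `COc1ccc(-n2cc(C(=O)Nc3ccc(Oc4ccnc5[nH]ccc45)cc3)c(=O)c3ccccc32)cc1`, gives 5950 nM.

Among these three numbers compound 1 stands second highest. Its nearest neighbour is compound 2, with a 2.0-fold lower number from compound 1 to compound 2 (0.30 log units; within the scatter). Its furthest is compound 3, with a 2.6-fold higher number from compound 1 to compound 3 (0.42 log units; beyond the scatter); between the other two the record shows a 5.3-fold higher number from compound 2 to compound 3 (0.73 log units; beyond the scatter).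

Compound 4, `O=C(Nc1ccc(Oc2ccnc3[nH]ccc23)c(F)c1)c1cn(-c2ccccc2)c2ccccc2c1=O`, is not yet measured. It differs from compound 1 by fluoro in place of hydrogen on an aromatic carbon. Among the measured compounds shown here, all three measured steps concern the group on the aromatic nitrogen of the shared core, none touches the anilide ring, so no measured step bears directly on this change. Without such a guide, the expectation for this assay is a step from compound 1 to compound 4 of no size beyond the scatter, a 1.1-fold lower number from compound 1 to compound 4 (0.05 log units; within the scatter), with the range kept wide. Compound 4 is therefore estimated at 2000 nM, within 700 nM to 6000 nM.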

Compound 4, half-maximal inhibitory concentration: 760 nM
Compound 4: middle estimate off by 2.6-fold (0.42 log units), on the high side, within the range that was stated.
By their numbers in this assay, from the lowest: compounds 4, 2 and 1 (each within the scatter of the next, the first and the last beyond it); then compound 3.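

In this assay, the six-membered aromatic ring of carbon only responds to substitution: fluoro in place of hydrogen, ortho to a large group and meta to a large group, gives a 3.0-fold lower number from compound 1 to compound 4 (0.47 log units; beyond the scatter). Among the compounds shown here, earlier steps concerned only the group on the aromatic nitrogen of the shared core, so this is the first measured sign that the number also moves with a change elsewhere in the molecule, here a single added fluorine atom. Nothing at hand accounts for the size or direction of this step.

Open, as far as these compounds go, is whether chloro, methoxy or an amine on this same carbon would move the number in the same direction as fluoro. Also open, from the compounds shown here alone, is whether fluoro gives a similar step when combined with the 3-chloro-4-fluorophenyl group of compound 2 or the 4-methoxyphenyl group of compound 3.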